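A few compounds are considered here, and "the series" means these few. Any claim that something is new, unique, unknown or untested is made for them only; others in the source may bear on it.

Measured so far:
compound 1 `Cn1nccc1-c1cccc2c1CCCN2c1ccc(C#N)c(C(F)(F)F)c1` gives 9800 nM in a functional assay on PC-3 cells (Homo sapiens) for antiproliferative activity, read by CCK-8 assay, with a stated time of 6 days; on this read-out lower numbers stand for stronger inhibition and higher numbers for weaker inhibition
compound 2 `CCN(c1ccc(C#N)c(Cl)c1)c1cc(-c2cncnc2)ccc1C` gives > 30000 nM in this assay

Compound 2 stands at the limit of this assay; its value is a limit and not a number (the limit of > 30000 nM in this assay, at which 1 of the 2 values shown sits). Compound 3 `CCN(c1ccc(C#N)c(Cl)c1)c1cc(-c2cn[nH]c2)ccc1C` differs from compound 2 by 1H-pyrazol-4-yl in place of pyrimidin-5-yl on an aromatic carbon. Among the measured compounds shown here, no step between measured compounds is available, so the size of this change cannot be read from the data; the step is expected to stay within the scatter or shift slightly toward stronger inhibition, as an at least 1.5-fold lower number from compound 2 to compound 3 (0.17 log units; that floor lies within the scatter). Compound 3 is accordingly estimated at 20000 nM, within 6000 nM to 60000 nM, with a fair chance that this assay again reports only a limit.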

Compound 3, half-maximal inhibitory concentration: 15300 nM
The estimate for compound 3 lay 1.3-fold (0.12 log units) above the measured number; the range from low to high includes it.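

In this assay, among the compounds shown here, 1H-pyrazol-4-yl in place of pyrimidin-5-yl, on the aromatic carbon para to a methyl group, gives the first step that can be read at this position, as an at least 1.9-fold lower number from compound 2 to compound 3 (0.29 log units; that floor lies within the scatter). Only a floor is known for this step, and it does not clear the usual scatter. Compound 2 gives only a limit and not a number: the limit of > 30000 nM in this assay, at which 1 of the 3 values shown sits.

On these data alone, whether an amine or a carboxylic acid on this carbon would give a lower number stays open. Compound 1 differs from compound 3 in more than one place, so it cannot show the effect of this change.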